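A few compounds are considered here, and "the series" means these few. Any claim that something is new, unique, unknown or untested is made for them only; others in the source may bear on it.

Measured in a functional assay on HCT-116 cells (Homo sapiens) for antiproliferative activity, read by MTT assay, with a stated time of 72 h; on this read-out lower numbers stand for stronger inhibition and higher numbers for weaker inhibition:
- Compound 1 `O=C(CCc1cccc2c1B(O)OC2)Nc1ccccc1` gives 350 nM
- Compound 2 `O=C(CCc1cccc2c1B(O)OC2)Nc1cccc(-c2ccc(Cl)cc2)c1` gives 380 nM
- Compound 3 `CSc1ccc(-c2cccc(NC(=O)CCc3cccc4c3B(O)OC4)c2)cc1` gives 180 nM

The position of compound 3 rests on two small steps. One is a 1.9-fold lower number from compound 1 to compound 3 (0.29 log units; within the scatter) and the other, a modest one, is a 2.1-fold lower number from compound 2 to compound 3 (0.32 log units; beyond the scatter). Compound 3 therefore separates from compound 2 but not from compound 1.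

Compound 4 `O=C(CCc1cccc2c1B(O)OC2)Nc1cccc(-c2cccc(C(F)(F)F)c2)c1` differs from compound 3 in one place, with 3-(trifluoromethyl)phenyl in place of 4-(methylsulfanyl)phenyl on an aromatic carbon. Among the measured compounds shown here, two measured steps bear on this change. Bringing in 4-chlorophenyl in place of hydrogen gave a 1.1-fold higher number from compound 1 to compound 2 (0.04 log units; within the scatter), and methylsulfanyl in place of chloro gave the modest step already noted. For the measured compounds named here, no measured compound carries a trifluoromethyl group, so the data offer no direct guide to its effect.

With methylsulfanyl gone, compound 4 is expected to drift towards compound 2 (380 nM). No step beyond the scatter is expected in this assay. The estimated step is a 1.7-fold higher number from compound 3 to compound 4 (0.22 log units; within the scatter) and its direction is uncertain. For compound 4 the estimated value is 300 nM, with an expected range from 130 nM to 700 nM.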

Compound 4, half-maximal inhibitory concentration: 580 nM
Compound 4: the middle estimate sits 1.9-fold (0.29 log units) below what was measured, and the stated range covers the measured number.
By their numbers in this assay, from the lowest: compounds 3, 1, 2 and 4 (each within the scatter of the next, the first and the last beyond it).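

In this assay the change from 4-(methylsulfanyl)phenyl to 3-(trifluoromethyl)phenyl gives a 3.2-fold higher number from compound 3 to compound 4 (0.51 log units; beyond the scatter) and so shows that, at this aromatic carbon, two large groups can be told apart beyond the scatter, though only modestly. The other two comparisons give a 1.5-fold higher number from compound 2 to compound 4 (0.18 log units; within the scatter) and a 1.7-fold higher number from compound 1 to compound 4 (0.22 log units; within the scatter) and neither step leaves the scatter, so compound 4 does not separate from compound 2 or from compound 1. Adding 3-(trifluoromethyl)phenyl in place of hydrogen, like adding 4-chlorophenyl, therefore leaves no readable mark on the number, and among the compounds shown only the 4-(methylsulfanyl)phenyl group of compound 3 separates from other large groups, while compound 3 itself still does not separate from compound 1.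

No measurement shown accounts for the step from compound 3 to compound 4. Going by these compounds, the step also changes both the group and its place on the added ring at once, so what each contributes stays open, as does how this assay would read an amine or a carboxylic acid on that ring.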